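The source may hold more compounds than are shown below. What is called first, only, known or untested is meant among the compounds shown, and "the series" means these compounds.

Notes on a set of stereoisomers followed in an ADME assay on liver (Mus musculus, strain C57BL/6) for metabolic stability, read by HPLC, with a stated time of 12 h; a lower number here means that the compound disappears faster, a higher number that the compound lasts longer. Compound 1 `O=C(O)[C@H](CO)NC(=O)[C@H]1C[C@H](O)CN1` reads > 12 h, which is a limit and not a number. Compound 2 `O=C(N[C@H](CO)C(=O)O)[C@@H]1C[C@H](O)CN1` reads > 12 h, again a limit. Compound 3 `O=C(O)[C@H](CO)NC(=O)[C@H]1C[C@@H](O)CN1`, the starting point for this step, reads > 12 h, also only a limit. The standing of compound 3 is therefore defined only by the limit of > 12 h in this assay, at which 3 of the 3 values shown sit, and it has no rank among the three.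

The next compound is compound 4 `O=C(O)[C@H](CO)NC(=O)[C@@H]1C[C@@H](O)CN1`, reached from compound 3 by the two compounds have the same atoms and bonds and differ only in configuration as drawn: 1 of 3 stereo elements differ; a stereocentre at a saturated ring carbon is drawn R in compound 3 and S in compound 4. Nothing leaves and nothing enters, and the atoms and bonds stay the same.

Within the data shown here, three measured steps bear on this change, all between compounds that differ only in configuration. The nearest in kind, with one stereo element changed at a saturated ring carbon, is a step that the two limits leave unreadable from compound 1 to compound 3. The other two are a step that the two limits leave unreadable from compound 1 to compound 2 and a step that the two limits leave unreadable from compound 2 to compound 3. None of them gives a size, but all three end at the same limit, so no step beyond the scatter is expected in this assay, and no direction is expected either. The estimate corresponds to a step that the limit leaves unreadable from compound 3 to compound 4, and the reading is expected to be a limit again. Compound 4 is estimated at 16 h, with an expected range of 12 h to 30 h.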

Compound 4, half-life: 0.27 h
Estimate against measurement, compound 4: 59-fold (1.77 log units) above; the measured number lies below the stated range.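

In this assay, inverting a single stereocentre at a saturated ring carbon gives an at least 44-fold lower number from compound 3 to compound 4 (1.64 log units; beyond the scatter), so this centre can change the read-out with the atoms and bonds left the same, something compound 1, compound 2 and compound 3 could not show, as all three stand at a limit of the assay and the steps among them cannot be read. The limit-bound comparisons with the other two compounds, each differing in two stereo elements, give an at least 44-fold lower number from compound 2 to compound 4 (1.64 log units; beyond the scatter) and an at least 44-fold lower number from compound 1 to compound 4 (1.64 log units; beyond the scatter), so compound 4 stands apart from all three earlier stereoisomers. The change can be assigned to configuration alone because of this: the fact that compounds 3 and 4 differ only in the configuration as drawn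

The compounds shown leave open how far each of the other stereocentres contributes, as compound 4 is the only one with a read number, and the size of each step remains bounded by the limits of the other compounds. As far as these compounds go, it also remains open whether the same configuration would matter with a methyl ester in place of the carboxylic acid, or with a methoxy group in place of the ring hydroxyl.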